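The compounds below may be only part of what the source reports. "The series", "measured", "known", "first", "only" and "open" are said of these compounds alone.

Measured so far in a physicochemical assay for solubility, using the shake flask method, measured as kinetic solubility, with a stated time of 2 h, at pH 7.4; on this read-out higher numbers stand for higher solubility and lower numbers for lower solubility:
- compound 1 `CN(Cc1ccccc1)c1cc(C(=O)Nc2ccccc2)ncn1`: < 5000 nM (a limit)
- compound 2 `CN(c1ccccc1)c1cc(C(=O)Nc2ccccc2)ncn1`: < 5000 nM (a limit)
- compound 3 `CN(Cc1ccccc1Cl)c1cc(C(=O)Nc2ccccc2)ncn1`: < 5000 nM (a limit)

Compound 3 gives < 5000 nM as a limit and not a number. Among the measured compounds shown here, the whole series so far stands there: the limit of < 5000 nM in this assay, at which 3 of the 3 values shown sit.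

Compound 4 `CN(Cc1cccnc1)c1cc(C(=O)Nc2ccccc2)ncn1` carries pyridin-3-yl in place of 2-chlorophenyl on a saturated chain carbon bound to a nitrogen on an aromatic ring.

For the measured compounds named here, three measured steps bear on this change. The nearest is a step that the two limits leave unreadable from compound 1 to compound 3 with chloro in place of hydrogen on an aromatic carbon. The other two are a step that the two limits leave unreadable from compound 1 to compound 2 and a step that the two limits leave unreadable from compound 2 to compound 3 and they concern the group on the nitrogen. None of the three gives a size, so the expectation rests on the structural change alone and stays loose.

A small upward move in this assay is expected, and the read-out may well remain a limit. The expected step is an at least 1.2-fold higher number from compound 3 to compound 4 (0.07 log units; that floor lies within the scatter) and it carries wide uncertainty. Compound 4 is estimated at 6000 nM with an expected range from 2000 nM to 30000 nM.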

Compound 4, solubility: 150000 nM
The estimate for compound 4 lay 25-fold (1.40 log units) below the measured number; the measured number lies above the stated range.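

In this assay, compound 4 is the only compound shown that gives a number and not a limit: the limit of < 5000 nM in this assay, at which 3 of the 4 values shown sit. On a saturated chain carbon bound to a nitrogen on an aromatic ring, pyridin-3-yl in place of 2-chlorophenyl gives an at least 30-fold higher number from compound 3 to compound 4 (1.47 log units; beyond the scatter), and pyridin-3-yl in place of phenyl gives an at least 30-fold higher number from compound 1 to compound 4 (1.47 log units; beyond the scatter). With (pyridin-3-yl)methyl in place of phenyl on a nitrogen on an aromatic ring, the result is an at least 30-fold higher number from compound 2 to compound 4 (1.47 log units; beyond the scatter), so this position can carry a large change, whereas the steps among compound 1, compound 2 and compound 3 cannot be read.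

As far as these compounds go, the full size of these three steps stays open, since each starts from a limit. Also open, from the compounds shown here alone, is whether other groups at this place, such as a morpholine or a carboxylic acid, would give a comparable step.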